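Three Inactive Compounds and an Untested Fourth

The source may hold more compounds than are shown below. What is called first, only, known or untested is meant among the compounds shown, and "the series" means these compounds.

Measured compounds:
Compound 1, `COc1cccc(N2CCN(CCCn3nc(-c4ccccc4)c(C#N)c3C)CC2)c1`, gives 0%.
Compound 2, `Cc1ccc(N2CCN(CCCn3nc(-c4ccccc4)c(C#N)c3C)CC2)cc1`, gives 0%.
Compound 3, `COc1cccc(N2CCN(CCCn3cccc3C(C)=O)CC2)c1`, gives 0%.

All three values come from a functional assay on the whole organism (Abdomen, strain Swiss) for inhibition, with Mus musculus as the target, with stated times of 30 min, 10 min and 5 min, at a dose of 10 mg/kg by the oral route; on this read-out lower numbers stand for a weaker effect and higher numbers for a stronger effect at the one dose given. Compound 1 and compound 2 share one core and differ in a single place: 4-methylphenyl in place of 3-methoxyphenyl on an amine nitrogen in a ring. This change made the step of no change at the digits printed from compound 1 to compound 2 (within the scatter), so at this dose neither compound shows any effect.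

Compound 3 is built on a different core; how the core of compound 1 and the core of compound 3 differ is not broken down here. In this assay compound 3 stands level with compound 1 and compound 2, giving no effect either.

Compound 4, `CC(=O)c1cccn1CCCN1CCN(c2ccc(C)cc2)CC1`, has not yet been measured. It is obtained from compound 3 by the same change that turned compound 1 into compound 2: 4-methylphenyl in place of 3-methoxyphenyl on an amine nitrogen in a ring. The surroundings of the place are described in the same words in both cases, so this is the same change, made on a different core.

The step from compound 3 to compound 4 is expected to be no change at the digits printed from compound 3 to compound 4 (within the scatter), because the same change earlier gave no change at the digits printed from compound 1 to compound 2 (within the scatter) and the starting point, compound 3, already shows no effect, as its value 0% tells. Compound 4 is therefore estimated at 0% in this assay, with a likely range from 0% to 10%. Going by the values given here, the only basis for this expectation is the single earlier step and the three measured values; nothing here shows that this change can raise inhibition on any core.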

Compound 4, a percentage reported as inhibition, in the whole organism at one dose (the size of the read-out at that dose, not a potency): 12%
Compound 4: middle estimate off by 12 percentage points, on the low side, outside the stated range (above it).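

On the core of compound 3, putting 4-methylphenyl in place of 3-methoxyphenyl on the amine nitrogen in the ring gives, in this assay, a number 12 percentage points higher from compound 3 to compound 4 (beyond the scatter). Set beside the earlier step on the core of compound 1, the new step cannot be told apart from it, even though only the new step stands clear of the scatter by itself: the same change on two cores in this assay, no change at the digits printed (within the scatter) from compound 1 to compound 2 and a number 12 percentage points higher (beyond the scatter) from compound 3 to compound 4, 12 percentage points apart, within the scatter of two such steps. This shows no firm sign that the core alters what the change does, but it does not show that the change carries over unaltered, since each core supplies a single pair of compounds and the effect on compound 4, at 12%, is small.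

The compounds shown leave open what other groups would do at this place on the piperazine-like ring, such as a plain phenyl or a 4-chlorophenyl, and whether either core would respond to them in the same way. They also leave open whether a longer chain linking that ring to the core, or a carboxylic acid on the core, would shift the read-out in this whole-animal test.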